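Trimming the Amide Side of Compound 2

This account rests on a few compounds, and the source may have more. Where it says the series, first, only, none or still open, it means among the compounds named here.

Compound 1 `COc1cc(-c2nn(-c3cccc(NC(=O)Nc4ccc(Cl)c(Cl)c4)c3)cc2-c2ccncc2)ccc1Cl` and compound 2 `COc1cc(-c2nn(-c3cccc(NC(=O)Nc4cccc(C(F)(F)F)c4)c3)cc2-c2ccncc2)ccc1Cl` share a core and differ only in the group on the amide-type nitrogen. In a functional assay on NCI/ADR-RES cells (Homo sapiens) for inhibition, read by sulforhodamine B assay, with a stated time of 48 h (a lower number here means a stronger inhibitor of growth, a higher number a weaker inhibitor of growth), compound 1 gives 4670 nM, and compound 2 gives 3640 nM; the step of a 1.3-fold lower number from compound 1 to compound 2 (0.11 log units; within the scatter) stays within the scatter, so compound 2 holds the lower of the two numbers without standing apart from compound 1. Compound 3 `COc1cc(-c2nn(-c3cccc(NC(=O)c4ccccc4)c3)cc2-c2ccncc2)ccc1Cl` carries phenyl in place of (3-(trifluoromethyl)phenyl)amino on a carbonyl carbon. Among the compounds with values here, no measured step touches this carbonyl carbon; the single known step alters a different part of the molecule and was small. Near the number of compound 2 lies the expectation for compound 3: an expected step of a 1.4-fold higher number from compound 2 to compound 3 (0.14 log units; within the scatter) and an estimated 5000 nM, between 2000 nM and 15000 nM.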

Compound 3, concentration for total growth inhibition: > 100000 nM
Compound 3 was reported as a limit (the forecaster's own chance of this, stated with the estimate: 10%); middle value at least 20-fold (1.30 log units) from the limit.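

In this assay the value of compound 3 is a limit of the assay and not a number: the limit of > 100000 nM in this assay, at which 1 of the 3 values shown sits.

Phenyl in place of the substituted phenylamino group on the carbonyl carbon gives an at least 27-fold higher number from compound 2 to compound 3 (1.43 log units; beyond the scatter) and an at least 21-fold higher number from compound 1 to compound 3 (1.33 log units; beyond the scatter), both large, whereas exchanging the aryl group on the amide-type nitrogen had stayed within the scatter. The change at this carbonyl carbon thus matters far more than that exchange, although it removes the nitrogen and the ring substituents together.

The compounds shown leave open which of these losses carries the step: an unsubstituted phenylamino group or a 3-(trifluoromethyl)phenyl group on this carbonyl carbon would separate them.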